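The source may report more compounds than this note shows. Statements on the series, on what has been measured and on what is new or still open speak of the compounds shown alone.

Working notes on the series. Compound 1 `COc1cc2ncnc(N3CCc4ccccc43)c2cc1NC(=O)/C=C/CN1CCCCC1` gives 2540 nM in a functional assay on A549 cells (Homo sapiens) for antiproliferative activity, read by MTT assay, with a stated time of 72 h; a lower number here means a stronger inhibitor, a higher number a weaker inhibitor. Compound 2 `COc1cc2ncnc(N3CCc4ccccc43)c2cc1NC(=O)/C=C/CN1CCN(C)CC1` differs from compound 1 only in the side chain, (4-methylpiperazin-1-yl in place of piperidin-1-yl on a saturated chain carbon bound to a double-bonded chain carbon), and in this assay compound 2 gives 5360 nM, so that a 2.1-fold higher number from compound 1 to compound 2 (0.32 log units; beyond the scatter). Compound 3 `O=C(/C=C/CN1CCCCC1)Nc1cc2c(N3CCCc4ccccc43)ncnc2cc1O[C@@H]1CCOC1` carries a different core; how that core differs from the core of compound 1 is not broken down here. In this assay compound 3 gives 3670 nM, which lies within the scatter of compound 1 and within the scatter of compound 2.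

Compound 4 `CN1CCN(C/C=C/C(=O)Nc2cc3c(N4CCCc5ccccc54)ncnc3cc2O[C@@H]2CCOC2)CC1` is not yet measured. It stands to compound 3 as compound 2 stands to compound 1: 4-methylpiperazin-1-yl in place of piperidin-1-yl on a saturated chain carbon bound to a double-bonded chain carbon, the same change at the same place. Since the step from compound 1 to compound 2 was a 2.1-fold higher number from compound 1 to compound 2 (0.32 log units; beyond the scatter), the same direction and about the same size is expected here, so that a 2.1-fold higher number from compound 3 to compound 4 (0.32 log units; beyond the scatter) is the expected step. The estimate for compound 4 in this assay is therefore 7700 nM, with the range 4000 nM to 15000 nM covering the scatter seen in one prior instance of the change.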

Compound 4, half-maximal inhibitory concentration: 5870 nM
Compound 4: the middle estimate sits 1.3-fold (0.12 log units) above what was measured; the measured number falls inside the stated range.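

In this assay, putting 4-methylpiperazin-1-yl in place of piperidin-1-yl on the core of compound 3 gives a 1.6-fold higher number from compound 3 to compound 4 (0.20 log units; within the scatter), so this step taken alone cannot be told apart from repeat measurement. Set beside the earlier step, it shows no detectable difference in how the change reads on the two cores: the same change on two cores in this assay, a 2.1-fold higher number (0.32 log units; beyond the scatter) from compound 1 to compound 2 and a 1.6-fold higher number (0.20 log units; within the scatter) from compound 3 to compound 4, 1.3-fold (0.12 log units) apart, within the scatter of two such steps This rests on only two pairs in a single assay, so it does not show that the step is real on the core of compound 3, nor that it would hold on any other core.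

The compounds shown leave open how other amines on the saturated chain carbon bound to a double-bonded chain carbon, such as morpholin-4-yl or dimethylamino, would read on either core. Also open, going by these compounds, is whether the two steps would stay alike with a longer chain carrying the same two rings.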